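This account rests on a few compounds, and the source may have more. Where it says the series, first, only, none or still open, it means among the compounds named here.

Measured compounds:
- compound 1 `CC1=C(C(C)CC(=O)OCC(C)COc2no[n+]([O-])c2S(=O)(=O)c2ccccc2)C(=O)c2c(O)cccc2C1=O`: 94.4%
- compound 2 `CC1=C(CCC(=O)OCCOc2no[n+]([O-])c2S(=O)(=O)c2ccccc2)C(=O)c2c(O)cccc2C1=O`: 97.6%
- compound 3 `CC1=C(CCC(=O)OCC(C)COc2no[n+]([O-])c2S(=O)(=O)c2ccccc2)C(=O)c2c(O)cccc2C1=O`: 97.4%

In a functional assay on MDA-MB-231 cells (Homo sapiens) for inhibition, read by MTT assay, with a stated time of 72 h, tested at 10 uM (a lower number here means less inhibition of growth, a higher number more inhibition of growth at the concentration tested), compound 1 gives 94.4%. The step of a number 3 percentage points higher from compound 1 to compound 3 (within the scatter) is within the scatter, and compound 2 with 97.6% is likewise within the scatter of compound 1, so on the numbers shown the three compounds cannot be told apart; all sit near complete inhibition of growth at the tested concentration. Compound 4 `CC1=C(C(C)CC(=O)OCCCOc2no[n+]([O-])c2S(=O)(=O)c2ccccc2)C(=O)c2c(O)cccc2C1=O` differs from compound 1 by hydrogen in place of methyl on a saturated chain carbon bound to two saturated chain carbons. Within the data shown here, the only measured step that bears on this, a number 3 percentage points higher from compound 1 to compound 3 (within the scatter), also removed a methyl from the chain, at another place, and changed nothing beyond the scatter. Compound 4 is therefore expected to show no step beyond the scatter, a number 0.4 percentage points lower from compound 1 to compound 4 (within the scatter). The estimate for compound 4 is 94%, between 85% and 99%.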

Compound 4, percent growth inhibition at one concentration: 95.3%
Compound 4: the middle estimate sits 1.3 percentage points below what was measured; measured number inside the range.
By their numbers in this assay, from the lowest: compounds 1, 4, 3 and 2 (each within the scatter of the next).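

Hydrogen in place of methyl on a saturated chain carbon bound to two saturated chain carbons gives a number 0.9 percentage points higher from compound 1 to compound 4 (within the scatter) in this assay at this dose. The earlier compounds shown here covered the loss of a methyl only at another chain carbon, so a second place on the chain now shows no difference that can be told from the scatter. Nothing available explains this result.

All four compounds sit near complete inhibition of growth at one concentration, so smaller differences among them could stay hidden. From the compounds shown here alone, whether an ethyl group or an amine on this carbon would give a similar reading remains open.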